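Phenyl in Place of Isopropyl: Estimating Compound 3

The compounds below may be only part of what the source reports. "The series", "measured", "known", "first", "only" and "open" are said of these compounds alone.

Compound 1 `NC(=O)[C@@H]1CCCN1C(=O)CCCCCCN1CCN(c2ccccc2-c2ccccc2)CC1` gives 18 nM in an assay on HEK293 cells for displacement of a labelled ligand from 5-hydroxytryptamine receptor 7 (Homo sapiens), with a stated time of 1 h; on this read-out lower numbers stand for stronger inhibition and higher numbers for weaker inhibition.
Compound 2 `CC(C)c1ccccc1N1CCN(CCCCC(=O)N2Cc3ccccc3C[C@H]2C(N)=O)CC1` gives 30 nM in this assay.

Compound 2 has the higher of the two numbers, but the gap to compound 1 lies within the usual scatter, so the two cannot be told apart on these data. Among the measured compounds shown here, the two compounds differ in several places at once, so no single step between them can be drawn.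

Compound 3 `NC(=O)[C@@H]1Cc2ccccc2CN1C(=O)CCCCN1CCN(c2ccccc2-c2ccccc2)CC1` keeps the whole core of compound 2 and changes one spot: phenyl in place of isopropyl on an aromatic carbon. The same group now sits on the aryl piperazine of compound 1, which carries no other change in that region; compound 1 gives 18 nM. On that basis, a step no larger than the scatter is expected from compound 2 to compound 3 in this assay, if anything toward a slightly lower number.

For compound 3 the estimate in this assay is 20 nM, with a range from 6 nM to 65 nM, which means an expected step of a 1.5-fold lower number from compound 2 to compound 3 (0.18 log units; within the scatter).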

Compound 3, inhibition constant: 12 nM
Estimate against measurement, compound 3: 1.7-fold (0.22 log units) above; low and high end bracket the measured number.
By their numbers in this assay, from the lowest: compounds 3, 1 and 2 (each within the scatter of the next, the first and the last beyond it).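

Phenyl in place of isopropyl on this aromatic carbon, ortho to a large group, gives a 2.5-fold lower number from compound 2 to compound 3 (0.40 log units; beyond the scatter) in this assay, and this is the only step shown between compounds that differ in one place. The position therefore holds a group of six carbon atoms in an aromatic ring where three carbon atoms stood before, and the number falls rather than rises. Nothing at hand explains why this step occurs.

From the compounds shown here alone, with only these two groups compared at this carbon, it remains open whether methyl, methoxy or a pyridyl ring, which brings a ring nitrogen, would give a similar number. Going by these compounds, it is also open whether isopropyl in place of phenyl would produce a matching step on the core of compound 1, with its longer chain.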